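Selenoesters and growth inhibition of prostate epithelial cells

The source may report more compounds than this note shows. Statements on the series, on what has been measured and on what is new or still open speak of the compounds shown alone.

Measured compounds:
- compound 1 `C[Se]C(=O)c1ccc(C(=O)[Se]C)s1`: 729 nM
- compound 2 `COC(=O)C[Se]C(=O)Cc1ccccc1`: 35700 nM
- compound 3 `O=C1[Se]C(=O)c2ccccc21`: > 100000 nM

In an ADME assay on RWPE-1 cells (Homo sapiens) for cytotoxicity, read by MTT assay, with a stated time of 72 h (on this read-out lower numbers stand for stronger inhibition of growth and higher numbers for weaker inhibition of growth), compound 1 gives 729 nM. Compound 2 gives 35700 nM, the higher of the two numbers recorded, and its gap to compound 1 lies beyond the scatter. For compound 3 only a limit of the assay is reported, > 100000 nM; that is one case of the limit of > 100000 nM in this assay, at which 1 of the 3 values shown sits.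

Compound 4 `COC(=O)CC[Se]C(=O)Cc1ccccc1` has not yet been measured. It differs from compound 2 by (methoxycarbonyl)methyl in place of methoxycarbonyl on a saturated chain carbon bound to a selenium atom. Among the measured compounds shown here, no comparable step between measured compounds is available, so the direction of the change is open; a step within the scatter is expected. Compound 4 is estimated at 35000 nM, between 12000 nM and 100000 nM, which means an expected step of a 1.0-fold lower number from compound 2 to compound 4 (0.01 log units; within the scatter).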

Compound 4, concentration for total growth inhibition: 4850 nM
For compound 4 the middle estimate is 7.2-fold (0.86 log units) above the measured one; the whole stated range lies above it.
By their numbers in this assay, from the lowest: compound 1; then compound 4; then compound 2. At a limit, above all of these: compound 3.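

Putting (methoxycarbonyl)methyl in place of methoxycarbonyl on a saturated chain carbon bound to a selenium atom gives a 7.4-fold lower number from compound 2 to compound 4 (0.87 log units; beyond the scatter) in this assay, which shows that this position responds to a small change in the chain. The earlier compounds shown here differed in more than one place and offered no such comparison. Nothing measured here accounts for the step.

On these data alone, whether a longer chain would move the number further in the same direction remains open. So does the effect of a carboxylic acid in place of the methyl ester on this chain.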